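The source may report more compounds than this note shows. Statements on the series, on what has been measured and on what is new or still open speak of the compounds shown alone.

Of the compounds shown here, three built on one shared core have been tested in a functional assay on PC-12 cells (Rattus norvegicus) for cytotoxicity, read by MTT assay, with a stated time of 24 h, tested at 1 uM; on this read-out higher numbers stand for a stronger effect at the one concentration tested and lower numbers for a weaker effect. Compound 1 `COc1ccc(C(c2ccc(OC)cc2)N2CCN(C(=O)COc3ccc4ccccc4c3)CC2)cc1` gives 5.42%, compound 2 `Cc1ccc(C(c2ccc(C)cc2)N2CCN(C(=O)COc3ccc4ccccc4c3)CC2)cc1` gives 5.63%, and compound 3 `COc1ccc(C(c2ccc(OC)cc2)N2CCN(C(=O)COc3ccccc3C)CC2)cc1` gives 3.75%. Compound 2 holds the highest of the three numbers, yet its gaps to compound 1 and to compound 3 both lie within the scatter. For the measured compounds named here, the only single change measured so far, a number 1.7 percentage points lower from compound 1 to compound 3 (within the scatter), replaces the naphthalen-2-yl on an oxygen on a saturated carbon and leaves the read-out essentially unchanged. Compound 4 `COc1ccc(OCC(=O)N2CCN(C(c3ccc(C)cc3)c3ccc(C)cc3)CC2)cc1` has not yet been measured; it differs from compound 2 by 4-methoxyphenyl in place of naphthalen-2-yl on an oxygen on a saturated carbon, again trading the naphthalen-2-yl on that oxygen for one six-membered aromatic ring of carbon only. The comparable step a number 1.7 percentage points lower from compound 1 to compound 3 (within the scatter) stayed within the scatter. The step of a number 0.6 percentage points lower from compound 2 to compound 4 (within the scatter) is therefore expected to be small. Compound 4 is estimated at 5%, between 1.5% and 9.5%.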

Compound 4, a percentage reported as activity, at one concentration (the size of the read-out at that concentration, not a potency): 42.3%
Beside the measured number, compound 4's estimate is 37.3 percentage points below it; the measured number lies above the stated range.
By their numbers in this assay, from the lowest: compounds 3, 1 and 2 (each within the scatter of the next); then compound 4.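

In this assay, this position is not silent: 4-methoxyphenyl in place of naphthalen-2-yl on an oxygen on a saturated carbon gives a number 36.7 percentage points higher from compound 2 to compound 4 (beyond the scatter) on the core of compound 2. The earlier swap, a number 1.7 percentage points lower from compound 1 to compound 3 (within the scatter), brought in a different single ring on a different core, so these compounds cannot separate the two influences. No measurement shown here explains the jump. Open, as far as these compounds go, is whether the methoxy group itself matters, which a plain phenyl or a phenyl carrying an amine on that oxygen would test. Also open, from the compounds shown here alone, is whether 4-methoxyphenyl acts the same way on the core of compound 1.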